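Pyrazole acid in place of the 4-carboxyphenyl group

A few compounds are considered here, and "the series" means these few. Any claim that something is new, unique, unknown or untested is made for them only; others in the source may bear on it.

In an ADME assay on the whole organism (strain C57BL/6J) for pharmacokinetics, with Mus musculus as the target, at a dose of 5 mg/kg by the oral route (on this read-out higher numbers stand for higher oral bioavailability and lower numbers for lower oral bioavailability), compound 2 `O=C(O)c1ccc(C2CC2c2ccc(OCc3c(-c4c(Cl)cccc4Cl)noc3C3CC3)cc2Cl)cc1` gives 44%. For the measured compounds named here, the only other measured member of the series, compound 1 `O=C(O)c1cccc(C2CC2c2ccc(OCc3c(-c4c(Cl)cccc4Cl)noc3C3CC3)cc2Cl)c1`, gives 53%. Compound 2 therefore has the lower of two numbers, but the two lie within the scatter and cannot be ranked.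

The next structure is compound 3 `CC(C)n1nc(C(=O)O)cc1C1CC1c1ccc(OCc2c(-c3c(Cl)cccc3Cl)noc2C2CC2)cc1Cl`, with this change: 3-carboxy-1-isopropyl-1H-pyrazol-5-yl in place of 4-carboxyphenyl on a saturated ring carbon. Here 3-carboxy-1-isopropyl-1H-pyrazol-5-yl stands in place of 4-carboxyphenyl on a saturated ring carbon, and the rest of the structure is unchanged.

Going by the values given here, one measured step bears on this place: a number 9 percentage points lower from compound 1 to compound 2 (within the scatter). Among the compounds with values here, that step exchanges only one carboxyphenyl group for another, so it is a weak guide. Within the data shown here, no measured compound has a five-membered aromatic ring with 2 hetero atoms at this place, or an isopropyl group. The data give no direction for the new step, so no shift beyond the scatter is expected, with wide uncertainty.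

The expected change is a number 4 percentage points lower from compound 2 to compound 3 (within the scatter). Compound 3 is estimated at 40%, within an expected range of 18% to 65%.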

Compound 3, oral bioavailability in the Mus musculus assay: 11%
Estimate against measurement, compound 3: 29 percentage points above, outside the stated range (below it).
By their numbers in the Mus musculus assay, from the lowest: compound 3; then compounds 2 and 1 (each within the scatter of the next).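

For the compounds shown here, in the Mus musculus assay, the exchange of a carboxyphenyl group for 3-carboxy-1-isopropyl-1H-pyrazol-5-yl on a saturated ring carbon is the first change at this place to go beyond the scatter: a number 33 percentage points lower from compound 2 to compound 3 (beyond the scatter), and a number 42 percentage points lower from compound 1 to compound 3 (beyond the scatter). The place is therefore not indifferent to the group it carries, whereas exchanging one carboxyphenyl group for the other left the number within the scatter. In a physicochemical assay for solubility (a lower number here means a less soluble compound, a higher number a more soluble compound), compound 2 gives 72000 nM and compound 3 gives 158000 nM. The same exchange goes the opposite way there, so a shortfall in solubility does not account for the lower oral bioavailability of compound 3: the measured solubility of compound 2, 72000 nM, and of compound 3, 158000 nM, a 2.2-fold higher number (0.34 log units; beyond the scatter)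

Still open, going by these compounds, is how much of the step belongs to the five-membered aromatic ring with 2 hetero atoms and how much to the isopropyl group, as both enter in one step; a methyl group in place of the isopropyl group, with the ring kept, would divide the two. Also open, on these data alone, is whether the low oral bioavailability stays when a primary amide stands in place of the carboxylic acid on the five-membered ring.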